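The source may report more compounds than this note shows. Statements on the series, on what has been measured and on what is new or still open speak of the compounds shown alone.

Measured so far in a functional assay on DLD-1 cells (Homo sapiens) for antiproliferative activity, read by CellTiter-Glo, with a stated time of 72 h; on this read-out lower numbers stand for stronger inhibition and higher numbers for weaker inhibition:

compound 1, `CC1CCN(C2CCN(S(=O)(=O)c3cccc(-c4ccccc4F)c3)CC2)CC1`, gives 10 nM
compound 2, `CC1CCN(C2CCN(S(=O)(=O)c3cccc(-c4ccc(F)cc4)c3)CC2)CC1`, gives 12 nM
compound 3, `Cc1cc(C)cc(-c2cccc(S(=O)(=O)N3CCC(N4CCC(C)CC4)CC3)c2)c1`, gives 41 nM

Compound 3 carries the highest number of the three in this assay; its nearest neighbour is compound 2, at a 3.4-fold higher number from compound 2 to compound 3 (0.53 log units; beyond the scatter), and its furthest is compound 1, at a 4.1-fold higher number from compound 1 to compound 3 (0.61 log units; beyond the scatter). Compounds 1 and 2 sit within the scatter of each other: a 1.2-fold higher number from compound 1 to compound 2 (0.08 log units; within the scatter).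

Compound 4 is `COc1ccc(-c2cccc(S(=O)(=O)N3CCC(N4CCC(C)CC4)CC3)c2)cc1`. It differs from compound 3 in one place: 4-methoxyphenyl in place of 3,5-dimethylphenyl on an aromatic carbon

Within the data shown here, the steps that bear on this change are those from the two fluorophenyl compounds into compound 3, a 4.1-fold higher number from compound 1 to compound 3 (0.61 log units; beyond the scatter) and a 3.4-fold higher number from compound 2 to compound 3 (0.53 log units; beyond the scatter), both modest rises on going to 3,5-dimethylphenyl. Among the measured compounds shown here, compound 4 returns to a single substituent on the entering phenyl ring, as in compound 2, so a step back toward the lower numbers of compounds 1 and 2 is expected in this assay, of roughly the size seen between compounds 2 and 3 but with wide uncertainty, since no methoxy compound has been measured. Compound 4 is estimated at 18 nM, range 7 nM to 45 nM, which means a step of a 2.3-fold lower number from compound 3 to compound 4 (0.36 log units; beyond the scatter) is expected.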

Compound 4, half-maximal inhibitory concentration: 23 nM
For compound 4 the middle estimate is 1.3-fold (0.11 log units) below the measured one; low and high end bracket the measured number.
By their numbers in this assay, from the lowest: compounds 1, 2, 4 and 3 (each within the scatter of the next, the first and the last beyond it).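

Compound 4 in this assay stays within the scatter on both sides of this change, with a 1.8-fold lower number from compound 3 to compound 4 (0.25 log units; within the scatter) and with a 1.9-fold higher number from compound 2 to compound 4 (0.28 log units; within the scatter) as the step for methoxy in place of fluoro. Only a 2.3-fold higher number from compound 1 to compound 4 (0.36 log units; beyond the scatter) goes beyond the scatter, so 4-methoxyphenyl stands apart from compound 1 alone, whereas 3,5-dimethylphenyl in compound 3 stood apart from both fluorophenyl compounds. No measurement available here accounts for these steps.

Open, as far as these compounds go, is whether a phenyl ring carrying an amine, a carboxylic acid or a nitrile at this place would keep numbers of this size. Also open, from the compounds shown here alone, is whether a longer alkoxy chain in place of methoxy would stay within the scatter of compound 4.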